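Shifting the methyl group from compound 3 to compound 4

The source may report more compounds than this note shows. Statements on the series, on what has been measured and on what is new or still open speak of the compounds shown alone.

Compound 1 `Cc1cn(C2CCN(Cc3cccc(OC4CCCC4)c3)CC2)c(=O)[nH]c1=O` gives 30300 nM in an ADME assay on MRC5 cells (Homo sapiens) for cytotoxicity, read by fluorescence and resazurin assay, with a stated time of 3 days (on this read-out lower numbers stand for stronger inhibition and higher numbers for weaker inhibition), as a measured number. Compound 2 `Cc1cn(C2CCN(Cc3cncc(Oc4cccc(Cl)c4)c3)CC2)c(=O)[nH]c1=O` gives > 64000 nM as a limit. Compound 3 `Cc1ccc(Oc2cccc(CN3CCC(n4cc(C)c(=O)[nH]c4=O)CC3)c2)cc1` gives > 64000 nM as a limit, so no number is known for it. Compound 4 `Cc1cccc(Oc2cccc(CN3CCC(n4cc(C)c(=O)[nH]c4=O)CC3)c2)c1` carries 3-methylphenyl in place of 4-methylphenyl on an oxygen on an aromatic ring with the rest unchanged. Going by the values given here, the only measured step bearing on this is an at least 2.1-fold higher number from compound 1 to compound 3 (0.32 log units; beyond the scatter) where 4-methylphenyl replaces cyclopentyl at that place, a different exchange. The expected change is an at least 1.0-fold lower number from compound 3 to compound 4 (0.02 log units; that floor lies within the scatter) and no step beyond the scatter is expected in this assay here. For compound 4 the estimate is 60000 nM with an expected range from 35000 nM to 100000 nM and quite possibly only a limit again.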

Compound 4, half-maximal inhibitory concentration: > 64000 nM
Compound 4: no number, only a limit; the forecaster's own chance of this, stated with the estimate: 70%; middle value at least 1.0-fold (0.02 log units) from the limit.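

In this assay compound 4 gives > 64000 nM, which is a limit and not a number. Compound 3 and compound 4 both stand at limits, so the step between them cannot be read and the methyl shift has no measurable size here. With 3-methylphenyl in place of cyclopentyl on the oxygen, the change is an at least 2.1-fold higher number from compound 1 to compound 4 (0.32 log units; beyond the scatter), the same direction already seen with 4-methylphenyl.

Any real difference between the two methylphenoxy compounds stays hidden at the ceiling: the limit of > 64000 nM in this assay, at which 3 of the 4 values shown sit. Also open, going by these compounds, is how an amine or a carboxylic acid on this aromatic ring would read in this assay.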